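From phenyl to 2-chlorophenyl: an expected growth inhibition

The source may report more compounds than this note shows. Statements on the series, on what has been measured and on what is new or still open speak of the compounds shown alone.

Measured in a functional assay on HL-60 cells (Homo sapiens) for inhibition, read by MTT assay, with a stated time of 48 h, tested at 10 uM; on this read-out lower numbers stand for less inhibition of growth and higher numbers for more inhibition of growth at the one concentration tested:
- compound 1 `Cc1oc2c([C@H]3CCN(C)C[C@H]3O)c(O)cc(O)c2c(=O)c1C(O)c1c(Cl)cccc1Cl`: 14%
- compound 2 `Cc1oc2c([C@H]3CCN(C)C[C@H]3O)c(O)cc(O)c2c(=O)c1C(O)c1csc([N+](=O)[O-])c1`: 45%
- compound 3 `CN1CC[C@H](c2c(O)cc(O)c3c(=O)cc(/C=C/c4ccccc4)oc23)[C@H](O)C1`: 91%

Of these three, compound 3 stands highest at 91%, beyond the scatter from both others. Compound 4 `CN1CC[C@H](c2c(O)cc(O)c3c(=O)cc(/C=C/c4ccccc4Cl)oc23)[C@H](O)C1` differs from it in one place: chloro in place of hydrogen on an aromatic carbon (ortho to a large group), so that phenyl becomes 2-chlorophenyl.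

Among the measured compounds shown here, only one measured step offers any guide. This is the large change a number 31 percentage points higher from compound 1 to compound 2 (beyond the scatter), where 5-nitrothiophen-3-yl replaces 2,6-dichlorophenyl. It shows that the number can respond strongly to an exchange of groups, but it is a much bigger exchange on a different chain. For the measured compounds named here, no measured pair tests chloro on the 2-phenylethenyl group. A modest step is therefore expected, more likely downward because compound 3 at 91% has little room to rise. The expected change is a number 7 percentage points lower from compound 3 to compound 4 (within the scatter). For compound 4 the estimated value is 84%, with an expected range of 60% to 97%.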

Compound 4, percent growth inhibition at one concentration: 61%
Compound 4: middle estimate off by 23 percentage points, on the high side; measured number inside the range.
By their numbers in this assay, from the lowest: compound 1; then compound 2; then compound 4; then compound 3.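

In this assay, the exchange of phenyl for 2-chlorophenyl gives a number 30 percentage points lower from compound 3 to compound 4 (beyond the scatter). Among the compounds shown here, this is the first direct test of the 2-phenylethenyl group, and it shows that the number responds to this position: one heavy atom on an aromatic carbon, ortho to a large group, is enough to move it beyond the scatter. Nothing available here accounts for the drop, as no supporting data bear on it.

The compounds shown leave open whether the loss belongs to chloro itself or would also follow from another group at the same place, such as fluoro, methoxy or an amine. They also leave open whether chloro elsewhere on the phenyl ring would give a similar step, or whether the same exchange would act alike with a longer chain in place of the ethenyl link.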